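The source may hold more compounds than are shown below. What is called first, only, known or untested is meant among the compounds shown, and "the series" means these compounds.

Working notes on the series. Compound 1 `O=C1/C(=C\c2ccc(Cl)cc2)S/C(=N/c2ccccc2)N1Cc1ccncc1` and compound 2 `CN(C)c1ccc(/C=C2/S/C(=N/c3ccccc3)N(Cc3ccncc3)C2=O)cc1` share one core and differ only at the aromatic ring on the exocyclic double bond. Going by the values given here, in a functional assay on MCF7 cells (Homo sapiens) for cytotoxicity, read by MTT assay, with a stated time of 48 h (a lower number here means a stronger inhibitor, a higher number a weaker inhibitor), compound 1 gives 54900 nM and compound 2 gives 76300 nM; the two values lie within the scatter of each other, so compound 2 stands alongside compound 1 with no separation the data can support, as the one measured step shows: a 1.4-fold higher number from compound 1 to compound 2 (0.14 log units; within the scatter).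

Compound 3 `O=C1/C(=C\c2cccc(O)c2)S/C(=N/c2ccccc2)N1Cc1ccncc1` is the next member. Relative to compound 2 the change is 3-hydroxyphenyl in place of 4-(dimethylamino)phenyl on a double-bonded chain carbon bound to a double-bonded ring carbon. Among the compounds with values here, the only measured step bears on it loosely, since it also swapped the substituent on that same aromatic ring and stayed within the scatter. On that basis the expected step in this assay is a 1.3-fold lower number from compound 2 to compound 3 (0.10 log units; within the scatter), with no change beyond the scatter anticipated in either direction. For compound 3 the estimated value is 60000 nM, expected to fall between 28000 nM and 130000 nM.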

Compound 3, half-maximal inhibitory concentration: 43600 nM
The estimate for compound 3 lay 1.4-fold (0.14 log units) above the measured number, and the stated range covers the measured number.
By their numbers in this assay, from the lowest: compounds 3, 1 and 2 (each within the scatter of the next).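

Compound 1 and compound 2 carry only 4-chlorophenyl and 4-(dimethylamino)phenyl on a double-bonded chain carbon bound to a double-bonded ring carbon, whereas 3-hydroxyphenyl brings a hydrogen-bond donor to that place. In this assay, replacing 4-(dimethylamino)phenyl with 3-hydroxyphenyl gives a 1.8-fold lower number from compound 2 to compound 3 (0.24 log units; within the scatter) and replacing 4-chlorophenyl with it gives a 1.3-fold lower number from compound 1 to compound 3 (0.10 log units; within the scatter) so all three groups stand within the scatter of one another, and this place shows no separation among the groups seen so far. Nothing at hand bears on the reason for these numbers.

The compounds shown leave open whether a carboxylic acid or an amine on this aromatic ring, or a longer chain in place of it, would separate from these three. They also leave open how the rest of the shared core contributes, since only this one place varies.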